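The compounds below may be only part of what the source reports. "The series", "measured", "known", "first", "only" and "open" are said of these compounds alone.

Of the compounds shown here, three that share one core have been tested in a functional assay on U-87MG ATCC cells (Homo sapiens) for cytotoxicity, read by MTT assay, with a stated time of 72 h; a lower number here means a stronger inhibitor, a higher number a weaker inhibitor. Compound 1 (`CN(C)CCn1cnnc1-c1cc(Oc2ccc(NC(=O)N/N=C/c3ccc(Cl)cc3Cl)cc2F)ccn1`) gives 2330 nM, the middle of the three numbers. Compound 2 (`CN(C)CCn1cnnc1-c1cc(Oc2ccc(NC(=O)N/N=C/c3c[nH]c4ccccc34)cc2F)ccn1`) gives 690 nM, and compound 3 (`COc1ccc(OC)c(/C=N/NC(=O)Nc2ccc(Oc3ccnc(-c4nncn4CCN(C)C)c3)c(F)c2)c1`) gives 6400 nM. Compound 4 (`COc1ccc(/C=N/NC(=O)Nc2ccc(Oc3ccnc(-c4nncn4CCN(C)C)c3)c(F)c2)c(OC)c1`) has not yet been measured. It differs from compound 1 on a carbon with a double bond to nitrogen, where 2,4-dimethoxyphenyl stands in place of 2,4-dichlorophenyl: 2,4-dimethoxyphenyl in place of 2,4-dichlorophenyl on a carbon with a double bond to nitrogen.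

The closest measured precedent is the change to 2,5-dimethoxyphenyl, a 2.7-fold higher number from compound 1 to compound 3 (0.44 log units; beyond the scatter), a modest step beyond the scatter. The change to 1H-indol-3-yl went the other way, a 3.4-fold lower number from compound 1 to compound 2 (0.53 log units; beyond the scatter). The remaining step, a 9.3-fold higher number from compound 2 to compound 3 (0.97 log units; beyond the scatter), shows how far the number moves at this one place among these compounds. Compound 4 also carries a dimethoxyphenyl group, so the expectation follows compound 3 at 6400 nM rather than compound 2. For the measured compounds named here, with only one dimethoxyphenyl compound measured, this expectation remains loose. A modest move to a higher number, and so to a weaker inhibitor, is expected, estimated as a 2.1-fold higher number from compound 1 to compound 4 (0.33 log units; beyond the scatter). The estimated value for compound 4 is 5000 nM, with an expected range of 2000 nM to 12000 nM.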

Compound 4, half-maximal inhibitory concentration: 12600 nM
Compound 4: the middle estimate sits 2.5-fold (0.40 log units) below what was measured; the whole stated range lies below it.
By their numbers in this assay, from the lowest: compound 2; then compound 1; then compounds 3 and 4 (each within the scatter of the next).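

For the compounds shown here, with the 2,4-dimethoxyphenyl group on the carbon with a double bond to nitrogen, the number rises again relative to the 2,4-dichlorophenyl group of compound 1, with a 5.4-fold higher number from compound 1 to compound 4 (0.73 log units; beyond the scatter), so compound 3 is no longer the only dimethoxyphenyl compound on the weaker side of compound 1. Going by these compounds alone, changing the 2,5-dimethoxyphenyl group to the 2,4-dimethoxyphenyl group gives a 2.0-fold higher number from compound 3 to compound 4 (0.29 log units; within the scatter), which means this pair cannot be told apart in this assay, while the distance to the 1H-indol-3-yl compound widens to an 18-fold higher number from compound 2 to compound 4 (1.26 log units; beyond the scatter), the only step at this position printed as large. No measurement here accounts for these differences, and the data give no reason for them.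

The compounds shown leave open how a phenyl ring carrying a single methoxy group or a single chlorine would read in this assay, so it cannot be said whether one such group is enough to move the number. Also open, going by these compounds, is whether the low number of compound 2 extends to other ring groups at this position, such as a pyridyl, a 1-methylindol-3-yl or a hydroxyphenyl group.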